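The compounds below may be only part of what the source reports. "The series", "measured", "known", "first", "only" and "open" are said of these compounds alone.

Measured so far in an ADME assay on Vero cells (Chlorocebus sabaeus) for cytotoxicity, read by fluorescence and resazurin assay, with a stated time of 3 days; a higher number here means that more compound is tolerated, a lower number that less compound is tolerated:
- compound 1, `COc1ccc(N/N=C2\C(=O)N(Cc3cn(O[C@@H]4O[C@H](CC(C)=O)[C@H](OC(C)=O)[C@H](OC(C)=O)[C@H]4OC(C)=O)nn3)c3ccccc32)cc1`, gives 62500 nM
- compound 2, `CC(=O)C[C@H]1O[C@@H](On2cc(CN3C(=O)/C(=N\Nc4ccc(C#N)cc4)c4ccccc43)nn2)[C@H](OC(C)=O)[C@@H](OC(C)=O)[C@H]1OC(C)=O`, gives 75500 nM
- compound 3, `COc1ccc(N/N=C2\C(=O)N(Cc3cn(O[C@@H]4O[C@H](CO)[C@H](O)[C@H](O)[C@H]4O)nn3)c3ccccc32)cc1`, gives 76200 nM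

The three numbers in this assay sit close together; all of the gaps between them are within the usual scatter of this kind of measurement, so no order among compound 1, compound 2 and compound 3 can be read from them.

Compound 1 and compound 2 differ in one place: cyano in place of methoxy on an aromatic carbon. The step this made in this assay was a 1.2-fold higher number from compound 1 to compound 2 (0.08 log units; within the scatter), which is within the scatter.

Compound 4, `N#Cc1ccc(N/N=C2\C(=O)N(Cc3cn(O[C@@H]4O[C@H](CO)[C@H](O)[C@H](O)[C@H]4O)nn3)c3ccccc32)cc1`, is not yet measured in this assay. It stands to compound 3 exactly as compound 2 stands to compound 1: cyano in place of methoxy on an aromatic carbon. The place of the change is described in the same words for both pairs, so it is the same change, made in all on two pairs among the compounds shown. How the core of compound 3 differs from the core of compound 1 is not broken down here.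

Within the data shown here, for compound 4 the step from compound 3 is expected to be a 1.0-fold higher number from compound 3 to compound 4 (0.02 log units; within the scatter), a small one, because the only earlier example of this change gave a 1.2-fold higher number from compound 1 to compound 2 (0.08 log units; within the scatter). The half-maximal cytotoxic concentration of compound 4 in this assay is therefore estimated at 80000 nM, with a likely range from 45000 nM to 140000 nM. A single earlier pair is a thin base, and the estimate rests on it alone.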

Compound 4, half-maximal cytotoxic concentration: 93700 nM
For compound 4 the middle estimate is 1.2-fold (0.07 log units) below the measured one, and the stated range covers the measured number.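

In this assay, cyano in place of methoxy on an aromatic carbon gives a 1.2-fold higher number from compound 3 to compound 4 (0.09 log units; within the scatter). The replacement therefore reads the same on both cores, with no difference between the two steps that stands out from the scatter: the same change on two cores in this assay, a 1.2-fold higher number (0.08 log units; within the scatter) from compound 1 to compound 2 and a 1.2-fold higher number (0.09 log units; within the scatter) from compound 3 to compound 4, 1.0-fold (0.01 log units) apart, within the scatter of two such steps. This shows only that the replacement leaves no readable mark on the half-maximal cytotoxic concentration on either core; it does not show that a measurable effect carries from one core to the other, since neither step is large enough to be told from repeat measurement, and two pairs are too few to support a rule for the series.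

Still open, from the compounds shown here alone, is whether a different group on the same aromatic carbon, such as an amine, a carboxylic acid or a longer alkyl chain, would also leave the number in this assay within the scatter of the methoxy compounds. Also open is whether the agreement seen with cyano and methoxy would hold on a third core, as the compounds shown offer only the core of compound 1 and the core of compound 3.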